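Trifluoromethyl for methyl on the aryl of compound 2

The source may hold more compounds than are shown below. What is called first, only, known or untested is meant among the compounds shown, and "the series" means these compounds.

Compound 2 `Cc1cccc(-c2onc3ccc(C(=O)O)cc23)c1` gives 150 nM in an assay for inhibition of inositol hexakisphosphate kinase 2 (Homo sapiens), read by colorimetric assay, coupled enzyme assay and malachite green, with a stated time of 120 min, in the presence of a further agent that is not named here; a lower number here means a stronger inhibitor, a higher number a weaker inhibitor. For the measured compounds named here, compound 1 `Cc1cccc(-c2onc3ccc(/C=C/C(=O)O)cc23)c1` gives 290 nM in this assay; the step of a 1.9-fold lower number from compound 1 to compound 2 (0.29 log units; within the scatter) is the only one measured so far. On these two numbers compound 2 has the lower value, but its separation from compound 1 lies within the scatter, so no order between them can be stated.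

Compound 3 `O=C(O)c1ccc2noc(-c3cccc(C(F)(F)F)c3)c2c1` is the next member: trifluoromethyl in place of methyl on an aromatic carbon. Going by the values given here, no measured step touches this part of the structure; the single step of a 1.9-fold lower number from compound 1 to compound 2 (0.29 log units; within the scatter) concerns the acid-bearing group on the other side of the shared core and says nothing about the aryl substituent. Among the compounds with values here, with no bearing step, no shift beyond the scatter is expected in this assay from the exchange.

Compound 3 is therefore expected at 150 nM, with a range of 50 nM to 450 nM. The expected step of no change at the digits printed from compound 2 to compound 3 (within the scatter) is estimated as a change within the scatter.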

Compound 3, half-maximal inhibitory concentration: 1460 nM
For compound 3 the middle estimate is 9.7-fold (0.99 log units) below the measured one; the whole stated range lies below it.
By their numbers in this assay, from the lowest: compounds 2 and 1 (each within the scatter of the next); then compound 3.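

In this assay the aryl substituent proves to be a sensitive position, with a 9.7-fold higher number from compound 2 to compound 3 (0.99 log units; beyond the scatter) on exchanging methyl for trifluoromethyl on this aromatic carbon. For the compounds shown here, this is the first step to lie beyond the scatter, whereas the earlier step at the acid-bearing group did not separate its two compounds, so the series so far reads more strongly at the aryl substituent than at the acid-bearing group. Nothing available here accounts for the size of this step.

Going by these compounds, how other groups on this aromatic carbon would read remains open, for example chlorine, methoxy or a nitrile, and also whether a plain hydrogen there would fall nearer compound 2 or compound 3. Also open, on these data alone, is whether the same exchange would give a similar step with 2-carboxyethenyl in place of carboxy, as in compound 1.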